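Phenethyl for 4-methoxyphenyl on the sulfur of compound 1

The compounds below may be only part of what the source reports. "The series", "measured", "known", "first", "only" and "open" are said of these compounds alone.

In a functional assay on A549 cells (Homo sapiens) for antiproliferative activity, read by CCK-8 assay, with a stated time of 72 h (a higher number here means a weaker inhibitor, a lower number a stronger inhibitor), compound 1 (`COc1ccc(SCc2ccc(C(=O)Nc3ccccc3N)cc2)cc1`) gives 2570 nM and stands in the middle of the three measured compounds. Compound 2 (`Nc1ccccc1NC(=O)c1ccc(CSc2nccc(C(F)(F)F)n2)cc1`) gives a lower 970 nM and compound 3 (`COc1ccc(SCc2ccc(C(=O)Nc3ccccc3N)cc2)cc1OC`) a higher 5680 nM in this assay here. Compound 4 (`Nc1ccccc1NC(=O)c1ccc(CSCCc2ccccc2)cc1`) carries phenethyl in place of 4-methoxyphenyl on a sulfur. Going by the values given here, the only measured single-place step is modest (a 2.2-fold higher number from compound 1 to compound 3 (0.34 log units; beyond the scatter)) and is methoxy in place of hydrogen on an aromatic carbon. Among the compounds with values here, it bears only loosely, as no measured compound carries phenethyl. No clear direction is therefore expected, and the estimated step stays within the scatter (a 1.2-fold higher number from compound 1 to compound 4 (0.07 log units; within the scatter)). For compound 4 the expected value is 3000 nM, with an estimated range from 1000 nM to 9000 nM in this series.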

Compound 4, half-maximal inhibitory concentration: 3250 nM
Compound 4: the middle estimate sits 1.1-fold (0.03 log units) below what was measured; low and high end bracket the measured number.
By their numbers in this assay, from the lowest: compound 2; then compounds 1, 4 and 3 (each within the scatter of the next, the first and the last beyond it).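

In this assay, phenethyl on the sulfur gives a step within the scatter (a 1.3-fold higher number from compound 1 to compound 4 (0.10 log units; within the scatter)). The exchange removes the oxygen and its hydrogen-bond acceptor at an equal heavy-atom count, so on this evidence neither is needed at this position to hold the number of compound 1. No evidence bearing on this result is available.

Still open, on these data alone, is whether benzyl, a longer chain, or an amine on the phenethyl ring would move the number beyond the scatter.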